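The compounds below may be only part of what the source reports. "The series", "measured", "known", "first", "only" and "open" are said of these compounds alone.

Among the measured compounds shown here, in an ADME assay on microsomes from liver (Homo sapiens) for metabolic stability (on this read-out lower numbers stand for a shorter-lived compound and higher numbers for a longer-lived compound), compound 1 `CC#C[C@@H](Cc1nnn[nH]1)c1ccc(OCc2ccc3sc(F)c(-c4ccccc4C)c3c2)cc1` gives 0.0667 h, the lower of the two numbers known so far. Compound 2 `CC#C[C@@H](Cc1nnn[nH]1)c1ccc(OCc2ccc3sc(F)c(-c4ccc(OCCOC)cc4C)c3c2)cc1` gives 1.95 h; that step is a 29-fold higher number from compound 1 to compound 2 (1.47 log units; beyond the scatter). Compound 3 `CC#C[C@@H](Cc1nnn[nH]1)c1ccc(OCc2ccc3sc(C#N)c(-c4ccccc4C)c3c2)cc1` has not yet been measured in this assay. It differs from compound 1 by cyano in place of fluoro on an aromatic carbon. For the measured compounds named here, the one measured step concerns a different change at a different place, so nothing measured speaks directly to this exchange; the expected step of a 1.5-fold higher number from compound 1 to compound 3 (0.18 log units; within the scatter) is therefore small, with no direction beyond the scatter. For compound 3 the estimate is 0.1 h, ranging from 0.03 h to 0.4 h.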

Compound 3, half-life: 0.0333 h
Compound 3: middle estimate off by 3.0-fold (0.48 log units), on the high side; the range from low to high includes it.
By their numbers in this assay, from the lowest: compounds 3 and 1 (each within the scatter of the next); then compound 2.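

In this assay, cyano in place of fluoro on the aromatic carbon next to the ring sulfur gives a 2.0-fold lower number from compound 1 to compound 3 (0.30 log units; within the scatter). At this position, then, adding a hydrogen-bond acceptor and one more heavy atom does not shift the half-life beyond the scatter. No available evidence bears on this result.

From the compounds shown here alone, whether a methyl or an amine at this position would move the half-life beyond the scatter remains open. So does whether the same exchange would give a similarly small step with the 2-methoxyethoxy group of compound 2 present.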